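Swapping the amide aryl group: from bromo to methoxy

This account rests on a few compounds, and the source may have more. Where it says the series, first, only, none or still open, it means among the compounds named here.

Measured compounds:
Compound 1 `O=C(Nc1cccc(-c2oc3cc(-c4ccc(F)cc4)ccc3c(=O)c2O)c1)c1ccc(F)cc1` — 14200 nM
Compound 2 `O=C(Nc1cccc(-c2oc3cc(-c4ccc(F)cc4)ccc3c(=O)c2O)c1)c1ccc(Br)cc1` — 8630 nM

Both compounds were tested in a functional assay on HCC1937 cells (Homo sapiens) for antiproliferative activity, read by CCK-8 assay, with a stated time of 72 h; on this read-out lower numbers stand for stronger inhibition and higher numbers for weaker inhibition. For the measured compounds named here, compound 2 gives the lowest of the two numbers, and its nearest neighbour is compound 1, which gives a higher one; the step of a 1.6-fold lower number from compound 1 to compound 2 (0.22 log units; within the scatter) is the only measured step and lies within the scatter, so the two compounds cannot be told apart on these data.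

Compound 3 `COc1cccc(C(=O)Nc2cccc(-c3oc4cc(-c5ccc(F)cc5)ccc4c(=O)c3O)c2)c1` has not yet been measured. It differs from compound 2 in one place: 3-methoxyphenyl in place of 4-bromophenyl on a carbonyl carbon. Compound 3 carries a 3-methoxyphenyl on the carbonyl carbon whose other neighbour is the amide-type nitrogen, where compound 2 carries a 4-bromophenyl.

Going by the values given here, only the step from compound 1 to compound 2 touches this part of the shared core, and it was within the scatter, so the data give no sign that changing this aryl group moves the number far. For compound 3 a step of about a 1.2-fold higher number from compound 2 to compound 3 (0.06 log units; within the scatter) in this assay is therefore expected, that is, no change beyond the scatter. Compound 3 is estimated at 10000 nM, with a range from 4000 nM to 25000 nM.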

Compound 3, half-maximal inhibitory concentration: 18900 nM
Compound 3: middle estimate off by 1.9-fold (0.28 log units), on the low side, and the stated range covers the measured number.
By their numbers in this assay, from the lowest: compounds 2, 1 and 3 (each within the scatter of the next, the first and the last beyond it).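

In this assay, 3-methoxyphenyl in place of 4-bromophenyl on the carbonyl carbon gives a 2.2-fold higher number from compound 2 to compound 3 (0.34 log units; beyond the scatter). For the compounds shown here, this is the first step at this position to lie beyond the scatter, so the aryl group here can shift the number, though only modestly. Against 4-fluorophenyl, the same 3-methoxyphenyl gives a 1.3-fold higher number from compound 1 to compound 3 (0.12 log units; within the scatter), which leaves compound 1 inseparable from either of the other two, so only compound 2 and compound 3 can be told apart, and no supporting data offer a reason for that gap.

The step from compound 2 to compound 3 changes both the substituent and its place on the ring, so these compounds cannot show which of the two matters for the number. They also leave open how this position would respond to an aryl ring carrying an amine or a carboxylic acid, or to a saturated group such as cyclohexyl on the same carbonyl carbon.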